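Urea to amide on the shared core: compound 4 outlook

The source may report more compounds than this note shows. Statements on the series, on what has been measured and on what is new or still open speak of the compounds shown alone.

Three measured ureas carry the shared core of compound 1 `O=C(Nc1cccc(-n2cc(-c3ccncc3)c(-c3cc(O)cc(Cl)c3)n2)c1)Nc1ccc(Cl)c(Cl)c1`. In a functional assay on OVCAR-4 cells (Homo sapiens) for inhibition, read by sulforhodamine B assay, with a stated time of 48 h, tested at 100 uM (on this read-out higher numbers stand for a weaker effect at the one concentration tested and lower numbers for a stronger effect), compound 1 gives 9%, compound 2 `COc1cc(Cl)cc(-c2nn(-c3cccc(NC(=O)Nc4ccc(Cl)c(C(F)(F)F)c4)c3)cc2-c2ccncc2)c1` gives -16% and compound 3 `COc1cc(Cl)cc(-c2nn(-c3cccc(NC(=O)Nc4ccc(Cl)c(Cl)c4)c3)cc2-c2ccncc2)c1` gives -4%, which places compound 3 second highest of the three. The steps seen so far are a number 13 percentage points lower from compound 1 to compound 3 (beyond the scatter) and a number 12 percentage points higher from compound 2 to compound 3 (beyond the scatter), both modest. Compound 4 `COc1cc(Cl)cc(-c2nn(-c3cccc(NC(=O)c4cccc(C(F)(F)F)c4)c3)cc2-c2ccncc2)c1` differs from compound 3 in one place: 3-(trifluoromethyl)phenyl in place of (3,4-dichlorophenyl)amino on a carbonyl carbon. For the measured compounds named here, no measured step touches the carbonyl side of the linker, so neither step transfers directly; the closest analogy, the trifluoromethyl exchange in a number 12 percentage points higher from compound 2 to compound 3 (beyond the scatter), stayed modest, and all three values sit near zero. The expected step is therefore none beyond the scatter, a number 4 percentage points higher from compound 3 to compound 4 (within the scatter). Compound 4 is estimated at 0%, within -20% to 20% in this assay.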

Compound 4, a percentage reported as activity, at one concentration (the size of the read-out at that concentration, not a potency): 74%
Beside the measured number, compound 4's estimate is 74 percentage points below it, and the stated range ends below it.
By their numbers in this assay, from the lowest: compound 2; then compound 3; then compound 1; then compound 4.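

The carbonyl side of the linker is far more sensitive than the ring substituents: in this assay, 3-(trifluoromethyl)phenyl in place of (3,4-dichlorophenyl)amino on a carbonyl carbon gives a number 78 percentage points higher from compound 3 to compound 4 (beyond the scatter), and the matching exchange gives a number 90 percentage points higher from compound 2 to compound 4 (beyond the scatter). Both steps are large, whereas a number 13 percentage points lower from compound 1 to compound 3 (beyond the scatter) and a number 12 percentage points higher from compound 2 to compound 3 (beyond the scatter) are modest. Nothing available accounts for this weaker effect.

This change replaces the urea with an amide and alters the aromatic substituents at once, so their separate contributions remain unresolved. From the compounds shown here alone, how a sulfonamide linker would behave on the shared core also remains open.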